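This account rests on a few compounds, and the source may have more. Where it says the series, first, only, none or still open, it means among the compounds named here.

Measured compounds:
- compound 1 `Cc1nc(-c2nc[nH]n2)ccc1-c1cnc2c(n1)N([C@H]1CC[C@@H](O)CC1)C(=O)CN2`: 100%
- compound 2 `CO[C@H]1CC[C@H](N2C(=O)CNc3ncc(-c4ccc(-c5nc[nH]n5)nc4C)nc32)CC1`: 82%

In an ADME assay on S9 fraction from liver (Homo sapiens) for metabolic stability, with a stated time of 60 min (a lower number here means that less of the compound is left, a higher number that more of the compound is left), compound 1 gives 100%, the highest of the two numbers recorded. Compound 2 gives 82%. Among the compounds with values here, the only measured step, a number 18 percentage points lower from compound 1 to compound 2 (beyond the scatter), comes from exchanging the hydroxyl of the cyclohexyl ring for a methoxy group, a modest drop that lies beyond the scatter.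

Compound 3 `Cc1nc(-c2nc[nH]n2)ccc1-c1cnc2c(n1)N(CCC1CCOCC1)C(=O)CN2` is derived from compound 1 by the change (2-(oxan-4-yl)ethyl in place of 4-hydroxycyclohexyl on an amide-type nitrogen in a ring). As in the step to compound 2, the hydrogen-bond donor of compound 1 is lost, and the new group is larger and open-chain at its point of attachment. Within the data shown here, the one step that bears on this, a number 18 percentage points lower from compound 1 to compound 2 (beyond the scatter), points downward, so a decrease of similar or somewhat larger size is expected, a number 30 percentage points lower from compound 1 to compound 3 (beyond the scatter). Compound 3 is therefore estimated at 70%, within a range of 45% to 95%.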

Compound 3, percent of the compound remaining: 100%
Estimate against measurement, compound 3: 30 percentage points below; measured number outside the range, above it.
By their numbers in this assay, from the lowest: compound 2; then compounds 1 and 3 (each within the scatter of the next).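

In this assay, replacing 4-hydroxycyclohexyl with 2-(oxan-4-yl)ethyl on the amide-type nitrogen gives no change at the digits printed from compound 1 to compound 3 (within the scatter), so at this position a group with 0 hydrogen-bond donors and a ring with 1 hetero atom can match the hydroxylated ring. Removing the hydroxyl therefore does not in itself go with a lower number, and the replacement of 4-methoxycyclohexyl with 2-(oxan-4-yl)ethyl gives a number 18 percentage points higher from compound 2 to compound 3 (beyond the scatter). No measurement available here explains why these groups differ.

As far as these compounds go, it remains open whether 2-cyclohexylethyl, which has a ring of carbon only, would hold the number in this assay. From the compounds shown here alone, the effect of a longer chain, or of an amine or carboxylic acid on the chain, also remains open.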